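The source may report more compounds than this note shows. Statements on the series, on what has been measured and on what is new or still open speak of the compounds shown alone.

Compound 1 `COc1cc(CNC(=S)NC(CCc2ccc(C(C)(C)C)cc2)COC(=O)C(C)(C)C)ccc1O` is one of three analogues measured in an assay on CHO cells for displacement of a labelled ligand from transient receptor potential cation channel subfamily V member 1 (Rattus norvegicus); a higher number here means a weaker inhibitor, a lower number a stronger inhibitor. In this assay compound 1 gives 36.5 nM, the highest of the three numbers. Compound 3 `COc1cc(CNC(=S)NCC(COC(=O)C(C)(C)C)Cc2ccc(C)c(C)c2)c(I)cc1O` gives 18.9 nM, a gap within the usual scatter, whereas compound 2 `COc1cc(CNC(=S)NCC(COC(=O)C(C)(C)C)Cc2ccc(C(C)(C)C)cc2)c(Br)cc1O` gives 12.8 nM, a gap beyond it. For the measured compounds named here, both carry a halogen on the aromatic ring that bears the hydroxy group, yet each also differs from compound 1 elsewhere, so no single step is known. Compound 4 `COc1cc(CNC(=S)NC(CCc2ccc(C(C)(C)C)cc2)COC(=O)C(C)(C)C)cc(Br)c1O` differs from compound 1 in one place: bromo in place of hydrogen on an aromatic carbon, ortho to a hydroxy group. Because compound 2 gives 12.8 nM and compound 3 gives 18.9 nM, a modest step downward is expected for compound 4, a 2.0-fold lower number from compound 1 to compound 4 (0.31 log units; beyond the scatter). Compound 4 is estimated at 18 nM, with a likely range from 7 nM to 50 nM.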

Compound 4, inhibition constant: 143 nM
Beside the measured number, compound 4's estimate is 7.9-fold (0.90 log units) below it; measured number above the stated range.
By their numbers in this assay, from the lowest: compounds 2, 3 and 1 (each within the scatter of the next, the first and the last beyond it); then compound 4.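

In this assay, for the compounds shown here, this is the first single change that can be read at this position: bromo in place of hydrogen, ortho to a hydroxy group, gives a 3.9-fold higher number from compound 1 to compound 4 (0.59 log units; beyond the scatter), so the change weakens binding on the core of compound 1. The halogen-bearing compounds 2 and 3 differ in other places too, so their numbers could not show this. No measurement shown accounts for the step. As far as these compounds go, it remains open whether chloro or a methyl group at this position would give a similar step, and whether bromo would act the same way on the cores of compounds 2 and 3.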